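The source may report more compounds than this note shows. Statements on the series, on what has been measured and on what is new or still open speak of the compounds shown alone.

Two compounds with the shared core were tested in a toxicity assay on THP-1 cells (Homo sapiens) for inhibition; on this read-out lower numbers stand for higher toxicity in this test and higher numbers for lower toxicity in this test. Compound 1 `COc1ccc(-c2cnc(NC(=O)c3cccc([N+](=O)[O-])c3)n2C)cc1` carries a nitro-substituted benzamide. In this assay compound 1 reaches only the limit > 100000 nM, not a number. Compound 2 `COc1ccc(-c2cnc(NC(=O)c3ccccc3F)n2C)cc1` carries a fluoro-substituted benzamide. In this assay compound 2 likewise gives only the limit > 100000 nM, not a number. For the measured compounds named here, compound 2 therefore stands at the limit of > 100000 nM in this assay, at which 2 of the 2 values shown sit, with no measured compound placed anywhere else. The step under consideration leads to compound 3 `COc1ccc(-c2cnc(NC(=O)c3ccccc3OC)n2C)cc1`, where the change is methoxy in place of fluoro on an aromatic carbon. Going by the values given here, no measured step offers a comparison for this change, so the expected size of the step is none beyond the scatter, with no direction favoured. Compound 3 is expected to sit near 100000 nM, with a range of 50000 nM to 300000 nM, which amounts to an estimated step of a number no higher from compound 2 to compound 3 (the limit leaves the size open); a result reported only as a limit is considered likely.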

Compound 3, half-maximal cytotoxic concentration: > 100000 nM
Compound 3 gave a limit, no number; the forecaster's own chance of this, stated with the estimate: 85%; the middle value lies on the limit itself.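

For the compounds shown here, compound 2 and compound 3 both give only a limit, not a number, so no step between them can be read in this assay: the limit of > 100000 nM in this assay, at which 3 of the 3 values shown sit. The compounds shown leave open how methoxy and fluoro compare in this assay, and whether any benzamide here reaches a numerical value.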